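Trifluoromethyl on an Aromatic Carbon of a Shared Core

The compounds below may be only part of what the source reports. "The series", "measured", "known", "first", "only" and "open" are said of these compounds alone.

Three compounds share one core: compound 1 `COC(=O)[C@@]1(C)CCC=C2[C@@H]1CC[C@@H](C)[C@]2(C)Cc1c[nH]c2ccccc12`, compound 2 `COC(=O)[C@@]1(C)CCC=C2[C@@H]1CC[C@@H](C)[C@]2(C)Cc1c[nH]c2c(C)cccc12` and compound 3 `COC(=O)[C@@]1(C)CCC=C2[C@@H]1CC[C@@H](C)[C@]2(C)Cc1c(C)[nH]c2ccccc12`. In a functional assay on HBL-100 cells (Homo sapiens) for inhibition, read by sulforhodamine B assay, with a stated time of 48 h (a higher number here means a weaker inhibitor of growth, a lower number a stronger inhibitor of growth), compound 1 gives 4500 nM, compound 2 gives 8000 nM, and compound 3 gives 14000 nM, the highest of the three numbers. Compound 4 `COC(=O)[C@@]1(C)CCC=C2[C@@H]1CC[C@@H](C)[C@]2(C)Cc1c(C)[nH]c2ccc(C(F)(F)F)cc12` differs from compound 3 by trifluoromethyl in place of hydrogen on an aromatic carbon. Going by the values given here, no measured step introduces a trifluoromethyl anywhere; the nearest guides are methyl additions on aromatic carbons, which gave a 1.8-fold higher number from compound 1 to compound 2 (0.25 log units; within the scatter) and a 3.1-fold higher number from compound 1 to compound 3 (0.49 log units; beyond the scatter). Both moved the number upward, one within the scatter and one modestly beyond it, so a small rise, or no change beyond the scatter, is expected in this assay. Compound 4 is therefore estimated at 16000 nM, within 5000 nM to 45000 nM. That expected step is a 1.1-fold higher number from compound 3 to compound 4 (0.06 log units; within the scatter).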

Compound 4, concentration for 50% growth inhibition: 16000 nM
Compound 4: middle estimate and measured number agree at the digits printed; the measured number falls inside the stated range.
By their numbers in this assay, from the lowest: compounds 1, 2, 3 and 4 (each within the scatter of the next, the first and the last beyond it).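

In this assay, putting trifluoromethyl on this aromatic carbon gives a 1.1-fold higher number from compound 3 to compound 4 (0.06 log units; within the scatter), so a group of 4 heavy atoms can sit here without moving the number beyond the scatter. The earlier steps shown here covered only methyl added to compound 1, whereas this step adds a different and larger group to a compound that already carries a methyl. No measurement shown explains why the number holds. From the compounds shown here alone, it remains open whether an amine or a carboxylic acid on this same carbon would also leave the number within the scatter, and whether trifluoromethyl would do so on compound 1.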